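Isopropyl to propyl: a small swap on a carbonyl

The source may report more compounds than this note shows. Statements on the series, on what has been measured and on what is new or still open speak of the compounds shown alone.

Measured in a functional assay on HL-60 cells (Homo sapiens) for inhibition, read by MTT assay, with a stated time of 72 h (on this read-out higher numbers stand for weaker inhibition and lower numbers for stronger inhibition), as follows:
Compound 1 `CN(C)c1nnc2nncn2n1` gives 4840 nM
Compound 2 `CC(C)C(=O)N1CCN(c2nnc3nncn3n2)CC1` gives 1610 nM
Compound 3 `OCC(CO)(CO)Nc1nnc2nncn2n1` gives > 100000 nM (a limit, not a number)

Compound 2 at 1610 nM has the lower of the two actual numbers, which here means the stronger inhibition. The nearest value belongs to compound 1 at 4840 nM and that gap lies beyond the usual scatter of repeated measurements. The entry for compound 3 at > 100000 nM is a limit of the assay and not a number.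

Compound 4 `CCCC(=O)N1CCN(c2nnc3nncn3n2)CC1` has not been measured yet. It carries the same atoms as compound 2, joined differently: propyl in place of isopropyl on a carbonyl carbon. For the measured compounds named here, no pair of measured compounds shows what such a swap does, so the main guide is compound 2 at 1610 nM itself. The expectation in this assay is therefore no step beyond the scatter, with no favoured direction. The expected change a 1.0-fold lower number from compound 2 to compound 4 (0.00 log units; within the scatter) is only an estimate and should stay small. Compound 4 is estimated at 1600 nM (expected range 700 nM to 3800 nM).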

Compound 4, half-maximal inhibitory concentration: 9840 nM
Compound 4: middle estimate off by 6.2-fold (0.79 log units), on the low side; measured number above the stated range.
By their numbers in this assay, from the lowest: compound 2; then compound 1; then compound 4. At a limit, above all of these: compound 3.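

In this assay the change from isopropyl to propyl on a carbonyl carbon brings a 6.1-fold higher number from compound 2 to compound 4 (0.79 log units; beyond the scatter) and so shows that this position responds to how its carbon atoms are joined, not only to how many there are. The two groups have the same count of carbon atoms, no ring, no hydrogen-bond donors or acceptors and no net charge, so the pair isolates the branch: the branched isopropyl goes with the stronger inhibition and the straight propyl with the weaker. The data shown give no measurement that explains why this swap matters.

A single pair cannot settle whether branching itself is what counts, and a cyclopropyl group, a tert-butyl group or a longer chain such as butyl on the same carbonyl carbon would test that more widely. On these data alone, how an amine or a carboxylic acid carried on that chain would read in this assay also stays open.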